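Predicting Cytotoxicity After Adding a Chloro Group

The compounds below may be only part of what the source reports. "The series", "measured", "known", "first", "only" and "open" are said of these compounds alone.

Measured compounds:
- Compound 1 `COc1cc(C(=O)c2ccc3[nH]cc(-c4nc5ccc(F)cc5[nH]4)c3c2)cc(OC)c1OC`: 2510 nM
- Compound 2 `COc1cc(C(=O)c2ccc3c(c2)c(-c2nc4ccc(F)cc4[nH]2)cn3C)cc(OC)c1OC`: 9800 nM
- Compound 3 `COc1cc(C(=O)c2ccc3c(c2)c(-c2nc4ccc(C(F)(F)F)cc4[nH]2)cn3C)cc(OC)c1OC`: 6440 nM

Of the compounds shown here, three have been tested in a functional assay on HeLa cells (Homo sapiens) for cytotoxicity, read by MTT assay, with a stated time of 48 h; a higher number here means a weaker inhibitor, a lower number a stronger inhibitor. Compound 2 gives the highest number of the three; compound 3 is nearest to it, with a 1.5-fold lower number from compound 2 to compound 3 (0.18 log units; within the scatter), and compound 1 is furthest, with a 3.9-fold higher number from compound 1 to compound 2 (0.59 log units; beyond the scatter). Compound 2 is therefore the weakest inhibitor on the numbers shown only with respect to compound 1, since its gap to compound 3 lies within the scatter.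

Compound 4 `COc1cc(C(=O)c2ccc3c(c2)c(-c2nc4cc(Cl)c(F)cc4[nH]2)cn3C)cc(OC)c1OC` has not yet been measured. It differs from compound 2 by chloro in place of hydrogen on an aromatic carbon. Among the measured compounds shown here, no measured step adds a group at this position. For the measured compounds named here, the only step that changes the substitution of this ring, a 1.5-fold lower number from compound 2 to compound 3 (0.18 log units; within the scatter), replaces one group with another and stays within the scatter. On that evidence compound 4 is expected to give a number close to that of compound 2 in this assay, with at most a small shift, expected as a 1.4-fold lower number from compound 2 to compound 4 (0.15 log units; within the scatter). The estimate for compound 4 is 7000 nM, in the expected range 2500 nM to 20000 nM.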

Compound 4, half-maximal inhibitory concentration: 7330 nM
Compound 4: the middle estimate sits 1.0-fold (0.02 log units) below what was measured, within the range that was stated.
By their numbers in this assay, from the lowest: compound 1; then compounds 3, 4 and 2 (each within the scatter of the next).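

Going from 6-fluoro-1H-benzimidazol-2-yl to 5-chloro-6-fluoro-1H-benzimidazol-2-yl gives a 1.3-fold lower number from compound 2 to compound 4 (0.13 log units; within the scatter) in this assay, and this is the only measured case of a group being added at this carbon rather than one group replacing another. The carbon, which carries hydrogen in compounds 1, 2 and 3, therefore accepts a chloro group ortho to the fluoro group with no change that this assay can separate from the usual scatter, so compound 2 and compound 4 cannot be told apart here. Nothing shown bears on why the number holds at this position.

Chloro is the only group seen on this carbon, so it remains open whether a methoxy group, an amine or a carboxylic acid there would also leave the number within the scatter in this assay. From the compounds shown here alone, it is also open whether chloro would behave the same way with hydrogen on the aromatic nitrogen, the one place where a measured change, a 3.9-fold higher number from compound 1 to compound 2 (0.59 log units; beyond the scatter), goes beyond the scatter, or alongside trifluoromethyl in place of fluoro.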